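Cyclohexyl to allyl: what to expect for compound 4

This account rests on a few compounds, and the source may have more. Where it says the series, first, only, none or still open, it means among the compounds named here.

Measured in a functional assay on HL-60 cells (Homo sapiens) for cytotoxicity, read by MTT assay, with a stated time of 48 h; on this read-out higher numbers stand for weaker inhibition and lower numbers for stronger inhibition:
- compound 1 `COc1ccc(Nc2n[n+]([O-])c3ccccc3[n+]2[O-])cc1` gives 900 nM
- compound 2 `[O-][n+]1nc(NC2CC2)[n+]([O-])c2ccccc21` gives 3600 nM
- compound 3 `[O-][n+]1nc(NC2CCCCC2)[n+]([O-])c2ccccc21` gives 2500 nM

Compound 3 lies within the scatter of compound 2, while compound 1 gives a lower number, beyond the scatter. The unmeasured compound 4 `C=CCNc1n[n+]([O-])c2ccccc2[n+]1[O-]` carries allyl in place of cyclohexyl on a nitrogen on an aromatic ring. Within the data shown here, one measured step bears on this change, the swap of cyclopropyl for cyclohexyl at the same place: a 1.4-fold lower number from compound 2 to compound 3 (0.16 log units; within the scatter). Among the measured compounds shown here, with that step as the only guide, no change beyond the scatter is expected in this assay. The expected step is a 1.2-fold higher number from compound 3 to compound 4 (0.08 log units; within the scatter). For compound 4 the estimated value is 3000 nM, with an expected range from 1500 nM to 6000 nM.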

Compound 4, half-maximal inhibitory concentration: 25800 nM
The estimate for compound 4 lay 8.6-fold (0.93 log units) below the measured number, and the stated range ends below it.
By their numbers in this assay, from the lowest: compound 1; then compounds 3 and 2 (each within the scatter of the next); then compound 4.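

In this assay, the nitrogen substituent proves able to move the number well beyond the scatter: allyl in place of cyclohexyl gives a large rise (a 10-fold higher number from compound 3 to compound 4 (1.01 log units; beyond the scatter)), and allyl in place of cyclopropyl gives a modest one (a 7.2-fold higher number from compound 2 to compound 4 (0.86 log units; beyond the scatter)). The earlier step between the two ring-bearing groups had stayed within the scatter, so it gave no sign of this sensitivity. No measurement offered here gives a reason for the rise.

The compounds shown leave open whether the higher number goes with the loss of the ring or with the double bond. A saturated propyl chain on the same nitrogen would separate the two.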